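A few compounds are considered here, and "the series" means these few. Any claim that something is new, unique, unknown or untested is made for them only; others in the source may bear on it.

Measured so far in a functional assay on Huh-7 cells (Homo sapiens) for cytotoxicity, read by MTT assay, with a stated time of 72 h (on this read-out lower numbers stand for higher toxicity in this test and higher numbers for lower toxicity in this test), as limits, not numbers:
- compound 1 `CS(=O)(=O)N1CCC2(CC1)OOC1(CCCCC1)OO2` gives > 100 ug/mL as a limit
- compound 2 `CCCCS(=O)(=O)N1CCC2(CC1)OOC1(CCCC1)OO2` gives > 100 ug/mL as a limit

Compound 2 gives > 100 ug/mL in this assay and this value is a limit of the assay, not a number. Going by the values given here, the series so far stands at the limit of > 100 ug/mL in this assay, at which 2 of the 2 values shown sit, and offers no measured step to work from.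

Compound 3 `O=S(=O)(c1ccc(F)cc1)N1CCC2(CC1)OOC1(CCCC1)OO2` carries 4-fluorophenyl in place of butyl on a sulfonyl sulfur, with 4-fluorophenyl in place of butyl on a sulfonyl sulfur as the counted change. No step beyond the scatter is expected in this assay and any movement should run toward lower numbers, so the estimated step is an at least 1.1-fold lower number from compound 2 to compound 3 (0.04 log units; that floor lies within the scatter) for now. This expectation rests on compound 2 at > 100 ug/mL as a limit. For compound 3 the expected value is 90 ug/mL within an estimated range of 35 ug/mL to 150 ug/mL and a limit of the assay may well be the outcome.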

Compound 3, half-maximal cytotoxic concentration: > 100 ug/mL
Compound 3 gave a limit, no number (the forecaster's own chance of this, stated with the estimate: 65%); middle value at least 1.1-fold (0.04 log units) away from the limit.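

No step can be read from compound 2 to compound 3 in this assay, as both values are limits of the assay: the limit of > 100 ug/mL in this assay, at which 3 of the 3 values shown sit.

The compounds shown leave open what actual number compound 1, compound 2 or compound 3 would give, and whether a change on the sulfonyl sulfur moves this read-out at all.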